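Mirror Image of a Thiourea Benzimidazole Cytotoxin

The compounds below may be only part of what the source reports. "The series", "measured", "known", "first", "only" and "open" are said of these compounds alone.

Of the compounds shown here, three sharing one core have been tested for their effect on the growth of HeLa cells in a functional assay on HeLa cells (Homo sapiens) for cytotoxicity, read by MTT assay; on this read-out lower numbers stand for stronger inhibition and higher numbers for weaker inhibition. Compound 2 `CC(C)C[C@@H](NC(=S)Nc1ccccc1)c1nc2ccccc2[nH]1` gives 12100 nM, the lowest number of the three. Compound 3 `CC(C)[C@@H](NC(=S)NCc1ccccc1)c1nc2ccccc2[nH]1` gives 12300 nM, and this sits within the usual scatter of the number for compound 2, so the two cannot be told apart. Compound 1 `CC(C)[C@H](NC(=S)Nc1cc(C(F)(F)F)cc(C(F)(F)F)c1)c1nc2ccccc2[nH]1` gives 28900 nM, a number clearly beyond the scatter above that of compound 2, so compound 1 is the weaker of that pair.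

Compound 4 `CC(C)C[C@H](NC(=S)Nc1ccccc1)c1nc2ccccc2[nH]1` is the mirror image of compound 2: the two compounds have the same atoms and bonds and differ only in configuration as drawn: 1 of 1 stereo elements differ; a stereocentre at a saturated chain carbon is drawn R in compound 2 and S in compound 4. Going by the values given here, no pair of measured compounds differs in this way, so nothing in the data shows how large a step such a change brings. Swapping the handedness of a single stereocentre can leave the number unchanged or shift it in either direction, and here the measured compounds offer no guide. The expected step from compound 2 to compound 4 in this assay is therefore a 1.5-fold higher number from compound 2 to compound 4 (0.17 log units; within the scatter), leaning toward a slightly higher number, with wide uncertainty. Compound 4 is thus estimated at 18000 nM in this assay, within a range from 6000 nM to 60000 nM.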

Compound 4, half-maximal inhibitory concentration: 29100 nM
Compound 4: the middle estimate sits 1.6-fold (0.21 log units) below what was measured; measured number inside the range.
By their numbers in this assay, from the lowest: compounds 2 and 3 (each within the scatter of the next); then compounds 1 and 4 (each within the scatter of the next).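

In this assay, the handedness of this one stereocentre turns out to matter, which no earlier comparison could show: moving from the form drawn R to the form drawn S gives a 2.4-fold higher number from compound 2 to compound 4 (0.38 log units; beyond the scatter). Going by these compounds alone, the step is modest, but it is the first measured step in this set, and it shows that the form drawn R of this pair inhibits more strongly, so the shape of the compound in space counts here and not only its atoms and bonds. The shift can be tied to this single stereocentre and to nothing else on the molecule, because no other difference separates the pair: the fact that compounds 2 and 4 differ only in the configuration as drawn

As far as these compounds go, this is still one pair, so it remains open whether the mirror images of compound 1 and compound 3 would shift in the same direction or by a similar amount. From the compounds shown here alone, it is also open whether the same gap between the two forms would persist with a longer chain at the stereocentre, with a carboxylic acid on that chain, or with a urea in place of the thiourea.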